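Sulfanyl to sulfonyl in the pentafluorophenyl series

A few compounds are considered here, and "the series" means these few. Any claim that something is new, unique, unknown or untested is made for them only; others in the source may bear on it.

In a functional assay on DU-145 cells (Homo sapiens) for inhibition, read by trypan blue exclusion, with a stated time of 96 h (a higher number here means a weaker inhibitor of growth, a lower number a stronger inhibitor of growth), compound 1 `O=C(/C(=C\c1ccc(O)c([N+](=O)[O-])c1)SCc1ccc(Br)cc1)c1c(F)c(F)c(F)c(F)c1F` gives 10000 nM and stands second highest of three numbers. Compound 3 `O=C(O)c1ccc(C(=O)/C(=C\c2ccc(O)c([N+](=O)[O-])c2)SCc2ccc(Br)cc2)cc1` gives 50000 nM and compound 2 `O=C(/C(=C\c1cc(Cl)cc(Cl)c1Cl)S(=O)(=O)Cc1ccc(Cl)cc1)c1ccc(Br)cc1` gives 1000 nM as the lowest. Compound 4 `O=C(/C(=C\c1ccc(O)c([N+](=O)[O-])c1)S(=O)(=O)Cc1ccc(Br)cc1)c1c(F)c(F)c(F)c(F)c1F` carries (4-bromobenzyl)sulfonyl in place of (4-bromobenzyl)sulfanyl on a double-bonded chain carbon bound to a carbonyl carbon and a double-bonded chain carbon. Going by the values given here, the one measured step (a 5.0-fold higher number from compound 1 to compound 3 (0.70 log units; beyond the scatter)) lies on a carbonyl carbon, so it bears only on the size of steps. Among the compounds with values here, no measured step covers this change. Compound 2 also holds a sulfonyl but differs elsewhere, so its value (1000 nM) is only a weak pointer. The step expected in this assay is modest and toward a lower number (a 3.3-fold lower number from compound 1 to compound 4 (0.52 log units; beyond the scatter)), with no change still possible. Compound 4 is estimated at 3000 nM with an expected range from 500 nM to 15000 nM in this read-out.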

Compound 4, concentration for 50% growth inhibition: 50000 nM
Compound 4: the middle estimate sits 17-fold (1.22 log units) below what was measured; the measured number lies above the stated range.
By their numbers in this assay, from the lowest: compound 2; then compound 1; then compounds 3 and 4 (each within the scatter of the next).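

In this assay, (4-bromobenzyl)sulfonyl in place of (4-bromobenzyl)sulfanyl on this double-bonded chain carbon gives a 5.0-fold higher number from compound 1 to compound 4 (0.70 log units; beyond the scatter), so here the change means weaker growth inhibition. Going by these compounds alone, this is the first measured step at this position, and the low number of compound 2 at 1000 nM cannot be credited to its sulfonyl, since that compound differs in other places too. Nothing on hand accounts for the step.

Still open, going by these compounds, is whether the step keeps its direction with 4-carboxyphenyl on the carbonyl carbon. On these data alone, how a sulfinyl or an amine would read at this position is also open.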